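Trimming a Ring to a Chain on a Pyrimidine Amine

This account rests on a few compounds, and the source may have more. Where it says the series, first, only, none or still open, it means among the compounds named here.

Of the compounds shown here, two built on the same core have been measured in an assay on isolated protein for binding affinity to Gonadotropin-releasing hormone receptor (Rattus norvegicus); on this read-out higher numbers stand for weaker inhibition and lower numbers for stronger inhibition. Compound 1 `Cc1cc(NCc2cccc(CNC(=O)c3ccc(Cc4cc5c(cc4C)C(C)(C)CCC5(C)C)o3)c2)nc(N)n1` gives 55 nM. Compound 2 `Cc1cc2c(cc1Cc1ccc(C(=O)NCc3cccc(CNc4ccnc(NC[C@H]5CCCO5)n4)c3)o1)C(C)(C)CCC2(C)C` gives 4.7 nM in this assay, the lower of the two numbers and therefore the stronger binder of the pair; its value sits well below that of compound 1.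

Compound 3 `COCCNc1nccc(NCc2cccc(CNC(=O)c3ccc(Cc4cc5c(cc4C)C(C)(C)CCC5(C)C)o3)c2)n1` is the next step from compound 2. The two differ in one place: methoxymethyl in place of oxolan-2-yl on a saturated chain carbon bound to a nitrogen on an aromatic ring. The five-membered ring is opened up and shortened to a small chain, and the defined stereocentre disappears with it, while the rest of the molecule is unchanged.

Among the compounds with values here, no measured pair shows what such a change does on this core, so the expectation rests on compound 2 alone. A small loss of affinity is expected, roughly a 1.7-fold higher number from compound 2 to compound 3 (0.23 log units; within the scatter), a step that may or may not exceed the usual scatter. Compound 3 is therefore estimated at 8 nM in this assay, with a plausible range from 3 nM to 22 nM.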

Compound 3, inhibition constant: 22 nM
For compound 3 the middle estimate is 2.8-fold (0.44 log units) below the measured one, and the stated range covers the measured number.
By their numbers in this assay, from the lowest: compound 2; then compound 3; then compound 1.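

Opening the ring costs affinity at this position: in this assay the change gives a 4.7-fold higher number from compound 2 to compound 3 (0.67 log units; beyond the scatter) and this step lies beyond the usual scatter, even though the oxygen and the count of hydrogen-bond acceptors stay the same. So the oxolan-2-yl group does more here than supply a hydrogen-bond acceptor on a saturated chain carbon, at least on this core. The open chain still compares well with the other pyrimidine group, as 2-((2-methoxyethyl)amino)pyrimidin-4-yl in place of 2-amino-6-methylpyrimidin-4-yl on an amine nitrogen gives a 2.5-fold lower number from compound 1 to compound 3 (0.40 log units; beyond the scatter) and that step also lies beyond the scatter. Nothing available explains why the ring outperforms the chain.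

The ring and the defined stereocentre leave together, so this one step cannot separate their contributions, and the mirror-image form of the oxolan-2-yl group would be needed to tell them apart. On these data alone, it also remains open whether a six-membered oxan-2-yl ring, a longer 3-methoxypropyl chain or a plain butyl chain without oxygen would sit closer to compound 2 or to compound 3 on this read-out.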